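The source may hold more compounds than are shown below. What is called first, only, known or untested is meant among the compounds shown, and "the series" means these compounds.

Measured so far:
compound 1, `COc1ccc(-c2nn3c(-c4cccs4)nnc3s2)cc1OC`: 0.93
compound 2, `c1csc(-c2nnc3sc(-c4cnccn4)nn23)c1`: 0.89

In an ADME assay on microsomes from liver (Homo sapiens), read by HPLC, using NADPH, with a stated time of 10 min (on this read-out higher numbers stand for higher hepatic extraction and lower numbers for lower hepatic extraction), compound 1 gives 0.93 and compound 2 gives 0.89. Compound 2 stands lowest of the two numbers, with compound 1 the nearest; the gap between them lies within the scatter, so no order can be read from it. Both values sit near the top of the scale.

Compound 3, `Cc1cc(-c2nn3c(-c4cccs4)nnc3s2)n[nH]1`, is not yet measured in this assay. The change from compound 2 is 5-methyl-1H-pyrazol-3-yl in place of pyrazin-2-yl on an aromatic carbon. Going by the values given here, no step between measured compounds covers a change of this kind, so the expectation rests on the two values shown only. Given that compound 2 gives 0.89 and compound 1 gives 0.93, a step no larger than the scatter is expected, in the downward direction if in any. The expected step is a number 0.050 lower from compound 2 to compound 3 (within the scatter). Compound 3 is estimated at 0.84, with a range from 0.68 to 0.95.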

Compound 3, hepatic extraction ratio in the liver assay: 0.79
For compound 3 the middle estimate is 0.050 above the measured one; the measured number falls inside the stated range.
By their numbers in the liver assay, from the lowest: compounds 3, 2 and 1 (each within the scatter of the next, the first and the last beyond it).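

Going by these compounds alone, in the liver assay, 5-methyl-1H-pyrazol-3-yl in place of pyrazin-2-yl on an aromatic carbon gives the first step at this position, a number 0.10 lower from compound 2 to compound 3 (within the scatter) and so no change can be read from it. In a physicochemical assay for solubility, measured as kinetic solubility (on this read-out higher numbers stand for higher solubility and lower numbers for lower solubility), compound 2 gives 30000 nM and compound 3 gives 58000 nM and the same exchange reads a 1.9-fold higher number from compound 2 to compound 3 (0.29 log units; within the scatter) so that neither read-out separates the six-membered ring from the five-membered ring with its hydrogen-bond donor. Nothing available speaks to what lies behind either step.

The compounds shown leave open whether an unsubstituted pyrazole would read differently from the methylated one. They also leave open whether an amine or a carboxylic acid at this position would give a step beyond the scatter in the liver assay or in the physicochemical assay.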